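Replacing 3-carbamoylphenyl with 6-methoxypyridin-3-yl in compound 3

The source may hold more compounds than are shown below. What is called first, only, known or untested is meant among the compounds shown, and "the series" means these compounds.

Compound 1 `Nc1ccc(S(=O)(=O)N2CCN(c3ncc(C(O)(C(F)(F)F)C(F)(F)F)cc3C#CCCO)CC2)cn1`: < 14 mL.min-1.g-1
Compound 2 `CC(C)(C)n1cc(-c2cc(C(O)(C(F)(F)F)C(F)(F)F)cnc2N2CCN(S(=O)(=O)c3ccc(N)nc3)CC2)cn1`: 86 mL.min-1.g-1
Compound 3 `NC(=O)c1cccc(-c2cc(C(O)(C(F)(F)F)C(F)(F)F)cnc2N2CCN(S(=O)(=O)c3ccc(N)nc3)CC2)c1`: 17 mL.min-1.g-1

All three were tested in an ADME assay (liver) for metabolic stability, with Liver microsome (Homo sapiens) as the target, using microsomes and NADPH, with a stated time of 30 min, tested at 1 uM; a lower number here means slower removal, a higher number faster removal of the compound. The entry for compound 1, < 14 mL.min-1.g-1, is a limit of the assay and not a number. Of the two true numbers, compound 3 holds the lower one, and the gap is a 5.1-fold lower number from compound 2 to compound 3 (0.70 log units; beyond the scatter). Swapping this one group has also given an at least 6.1-fold higher number from compound 1 to compound 2 (0.78 log units; beyond the scatter), and an at least 1.2-fold higher number from compound 1 to compound 3 (0.08 log units; that floor lies within the scatter).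

Compound 4 `COc1ccc(-c2cc(C(O)(C(F)(F)F)C(F)(F)F)cnc2N2CCN(S(=O)(=O)c3ccc(N)nc3)CC2)cn1` carries 6-methoxypyridin-3-yl in place of 3-carbamoylphenyl on an aromatic carbon. Each of these two groups holds one six-membered aromatic ring, whereas compound 2 differs from compound 3 by a larger change of group, which gave a 5.1-fold lower number from compound 2 to compound 3 (0.70 log units; beyond the scatter). A smaller step than that is therefore expected, tilted upward because compound 3 already stands low at 17 mL.min-1.g-1. The expected step is a 1.8-fold higher number from compound 3 to compound 4 (0.25 log units; within the scatter). For compound 4 the estimated value is 30 mL.min-1.g-1, with an expected range from 14 mL.min-1.g-1 to 65 mL.min-1.g-1.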

Compound 4, intrinsic clearance in microsomes: 25 mL.min-1.g-1
For compound 4 the middle estimate is 1.2-fold (0.08 log units) above the measured one; the measured number falls inside the stated range.
By their numbers in this assay, from the lowest: compounds 3 and 4 (each within the scatter of the next); then compound 2. At a limit, below all of these: compound 1.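

In this assay, two different groups with one six-membered aromatic ring now sit at this position, and the swap gives a 1.5-fold higher number from compound 3 to compound 4 (0.17 log units; within the scatter), even though 3-carbamoylphenyl has 1 hydrogen-bond donor and 6-methoxypyridin-3-yl has 0. The second such group also stays apart from the pyrazole compound, with a 3.4-fold lower number from compound 2 to compound 4 (0.54 log units; beyond the scatter), so among the numbers shown, 1-(tert-butyl)-1H-pyrazol-4-yl stands alone at the high end. The remaining step, an at least 1.7-fold higher number from compound 1 to compound 4 (0.25 log units; that floor lies within the scatter), cannot be read as a size, one of its two entries being a limit of the assay and not a number: the limit of < 14 mL.min-1.g-1 in this assay, at which 1 of the 4 values shown sits.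

The compounds shown do not separate the ring nitrogen from the methoxy group of 6-methoxypyridin-3-yl, which a plain phenyl or a 4-methoxyphenyl group would do. Nor do they tell whether the higher number of compound 2 goes with its tert-butyl group or its pyrazole, which a methyl on the same pyrazole would test.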